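This account rests on a few compounds, and the source may have more. Where it says the series, first, only, none or still open, it means among the compounds named here.

Of the compounds shown here, three share one core and have been tested in a functional assay on PC-3 cells (Homo sapiens) for cytotoxicity, read by MTT assay, with a stated time of 72 h, tested at 1 uM; on this read-out higher numbers stand for a weaker effect at the one concentration tested and lower numbers for a stronger effect. Compound 1 `O=C(Nc1nc2cc(Sc3ccccc3)ccc2[nH]1)OC1COC1` gives 107% in this assay. Compound 2 `O=C(Nc1nc2cc(C(=O)c3ccccc3)ccc2[nH]1)OC1COC1` gives 90.9% in this assay. Going by the values given here, exchanging one group on the ring, benzoyl in place of phenylsulfanyl on an aromatic carbon, is the one measured step: a number 16.1 percentage points lower from compound 1 to compound 2 (beyond the scatter). Compound 3 `CCCSc1ccc2[nH]c(NC(=O)OCCCN(C)C)nc2c1` gives 95.5% in this assay; it lies below compound 1 by more than the scatter, while its gap to compound 2 falls within the scatter, so the two cannot be ordered.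

Compound 4 `CCCSc1ccc2[nH]c(NC(=O)OC3COC3)nc2c1` differs from compound 3 only in the group attached through the oxygen next to the carbonyl group: oxetan-3-yl in place of 3-(dimethylamino)propyl on an oxygen next to a carbonyl group. Among the compounds with values here, no measured pair changes this part of the molecule, so the step from compound 1 to compound 2 does not bear on it, and no measured step does. With nothing pointing either way, no change beyond the scatter is expected: a number 1.5 percentage points higher from compound 3 to compound 4 (within the scatter). Compound 4 is therefore estimated to give about 97%, somewhere between 80% and 110%.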

Compound 4, a percentage reported as activity, at one concentration (the size of the read-out at that concentration, not a potency): 95.2%
For compound 4 the middle estimate is 1.8 percentage points above the measured one; low and high end bracket the measured number.
By their numbers in this assay, from the lowest: compounds 2, 4 and 3 (each within the scatter of the next); then compound 1.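

In this assay, going by these compounds alone, the first measured change on the oxygen next to a carbonyl group, oxetan-3-yl in place of 3-(dimethylamino)propyl, gives a number 0.3 percentage points lower from compound 3 to compound 4 (within the scatter), so exchanging this open chain for a four-membered ring has no effect that can be told from the scatter. On the sulfur, propyl in place of phenyl gives a number 11.8 percentage points lower from compound 1 to compound 4 (beyond the scatter), a modest step showing that the group on the sulfur can shift this read-out. Propylsulfanyl in place of benzoyl on an aromatic carbon gives a number 4.3 percentage points higher from compound 2 to compound 4 (within the scatter), so these two groups cannot be told apart here.

Nothing available explains any of these steps. Whether a carboxylic acid on that oxygen or a longer chain on the sulfur would shift the number stays open, as does the behaviour of these compounds at other concentrations.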